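Methoxy in Place of Trifluoromethyl on the Amide Ring

The source may hold more compounds than are shown below. What is called first, only, known or untested is meant among the compounds shown, and "the series" means these compounds.

Of the compounds shown here, two sharing one core have been tested in a toxicity assay on HepG2 cells (Homo sapiens) for inhibition, read by CellTiter-Glo, with a stated time of 48 h; a higher number here means a weaker inhibitor, a lower number a stronger inhibitor. Compound 1 `COc1ccc2nc(C)cc(OCC(=O)Nc3cc(F)cc(F)c3)c2c1` gives only a limit, > 100000 nM, not a number. Among the compounds with values here, compound 2 `COc1ccc2nc(C)cc(OCC(=O)Nc3ccc(Cl)c(C(F)(F)F)c3)c2c1` is the one compound with a number, giving 79400 nM in this assay, so it stands as the only measured point. Compound 1 sits at the limit of > 100000 nM in this assay, at which 1 of the 2 values shown sits. Compound 3 `COc1ccc2nc(C)cc(OCC(=O)Nc3ccc(Cl)c(OC)c3)c2c1` has not yet been measured. It differs from compound 2 in a single place: methoxy in place of trifluoromethyl on an aromatic carbon. Within the data shown here, no two measured compounds differ by only one change, so no measured step exists to guide this swap. Because compound 2 gives 79400 nM, a value near where this assay stops reporting numbers, the step is expected to stay within scatter. The expected step of a 1.1-fold higher number from compound 2 to compound 3 (0.05 log units; within the scatter) is therefore small. For compound 3 the estimate in this assay is 90000 nM, with a range from 40000 nM to 200000 nM.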

Compound 3, half-maximal inhibitory concentration: > 100000 nM
Compound 3 gave a limit, no number; the forecaster's own chance of this, stated with the estimate: 55%; middle value at least 1.1-fold (0.04 log units) from the limit.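

In this assay, methoxy in place of trifluoromethyl on this aromatic carbon, ortho to a chloro group, gives an at least 1.2-fold higher number from compound 2 to compound 3 (0.10 log units; that floor lies within the scatter). Compound 3 carries a limit and not a number, so this step is only a floor, and the change did not yield a second measured value to set beside that of compound 2. The set now rests mostly on limits: the limit of > 100000 nM in this assay, at which 2 of the 3 values shown sit.

The step between compound 1 and compound 3 cannot be read, as both values are limits, so the two amide rings cannot be ranked against each other. Going by these compounds, it remains open whether an amine or a carboxylic acid on this same carbon would give a readable number in this assay, and how far above the limit compound 3 truly lies.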